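Flipping one double bond in compound 1

The source may report more compounds than this note shows. Statements on the series, on what has been measured and on what is new or still open speak of the compounds shown alone.

- Compound 1 `CC(C)CC(=O)O[C@@H]1OC=C(CO)[C@H]2C[C@H](O)[C@](O)(COC(=O)/C=C\c3ccc(O)cc3)[C@@H]12` gives 4560 nM
- Compound 2 `CC(C)CC(=O)O[C@@H]1OC=C(CO)[C@H]2C[C@H](OC(=O)/C=C/c3ccc(O)cc3)[C@](O)(CO)[C@@H]12` gives 2890 nM

Both numbers come from a functional assay on HeLa S3 cells (Homo sapiens) for cytotoxicity, read by WST assay; a higher number here means a weaker inhibitor, a lower number a stronger inhibitor. The values of compound 1 and compound 2 lie within the usual scatter of each other, so compound 1 cannot be ranked apart from compound 2 on these data.

Compound 3 `CC(C)CC(=O)O[C@@H]1OC=C(CO)[C@H]2C[C@H](O)[C@](O)(COC(=O)/C=C/c3ccc(O)cc3)[C@@H]12` has not been measured yet. Its relation to compound 1 is the two compounds have the same atoms and bonds and differ only in configuration as drawn: 1 of 6 stereo elements differ; a double bond is drawn Z in compound 1 and E in compound 3. In plain terms, a double bond is drawn Z in compound 1 and E in compound 3, while everything else stays the same.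

Going by the values given here, no pair of measured compounds shows what such a change does, so the data give no size or direction for this step. In this assay, no step beyond the scatter is expected, and the estimate stays close to compound 1 at 4560 nM. The expected change is small, an estimated step of a 1.3-fold lower number from compound 1 to compound 3 (0.11 log units; within the scatter). For compound 3, the estimated value is 3500 nM, with an expected range from 1500 nM to 8000 nM.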

Compound 3, half-maximal inhibitory concentration: 3570 nM
Compound 3: the middle estimate sits 1.0-fold (0.01 log units) below what was measured; the measured number falls inside the stated range.
By their numbers in this assay, from the lowest: compounds 2, 3 and 1 (each within the scatter of the next).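

Going by these compounds alone, until now, no pair of compounds isolated a single change, so nothing could be said about the size of any step. The pair of compound 1 and compound 3 supplies the first such step, and in this assay the change from the Z to the E double bond amounts to a 1.3-fold lower number from compound 1 to compound 3 (0.11 log units; within the scatter). This makes the comparison an unusually clean one, since no group enters or leaves and the step can be assigned to this one double bond alone: the fact that compounds 1 and 3 differ only in the configuration as drawn. At this position, then, the drawn geometry of the double bond gives no difference that can be told apart from the scatter of repeated measurements, although this rests on a single pair in a single cell assay.

The compounds shown leave open whether the double bond would matter in the same small way with the ester placed as it is in compound 2. They also leave open what would follow if the link itself changed, for example with an amide in place of the ester or a saturated chain in place of the double bond.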